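From Compound 3 to Compound 4: One Ring Exchanged

The source may report more compounds than this note shows. Statements on the series, on what has been measured and on what is new or still open speak of the compounds shown alone.

Three measured compounds share one core and differ only in the aromatic groups attached to it. In an in vitro functional assay on HEK285-7 cells for antagonist activity at prostaglandin D2 receptor 2 (Homo sapiens), read by BRET and beta-arrestin recruitment (a higher number here means a larger maximal response, a lower number a smaller maximal response), compound 1 `O=C(O)Cc1sc(C(c2ccccc2)c2ccc(F)cc2)nc1-c1ccc(Cl)cc1` gives 80%. Compound 2 `O=C(O)Cc1sc(C(c2ccccc2)c2ccccc2)nc1-c1cccc(F)c1` gives 80% in this assay. Compound 3 `O=C(O)Cc1sc(C(c2ccc(F)cc2)c2ccc(F)cc2)nc1-c1cc(F)nc(F)c1` gives 80% in this assay, level with compounds 1 and 2 at the digits shown, so all three values lie within the usual scatter of each other.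

Compound 4 `N#Cc1cc(-c2nc(C(c3ccc(F)cc3)c3ccc(F)cc3)sc2CC(=O)O)ccc1F` has not yet been measured. It differs from compound 3 in one place: 3-cyano-4-fluorophenyl in place of 2,6-difluoropyridin-4-yl on an aromatic carbon. With every measured value sitting at the same level, no step beyond the scatter is expected here, and the step is estimated as no change at the digits printed from compound 3 to compound 4 (within the scatter). Compound 4 is expected to give about 80% in this assay, within a range from 65% to 92%.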

Compound 4, largest response reached (reported as efficacy), in percent of the reference or control that the assay uses: 80%
Beside the measured number, compound 4's estimate shows no gap at the digits printed; the measured number falls inside the stated range.
By their numbers in this assay, from the lowest: compounds 1, 2, 3 and 4 (each within the scatter of the next).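

Among the compounds shown here, the first one-place comparison comes at this ring carbon: in this assay, replacing 2,6-difluoropyridin-4-yl with 3-cyano-4-fluorophenyl gives no change at the digits printed from compound 3 to compound 4 (within the scatter). So at this position, a carbon-only ring carrying a nitrile and a fluorine reads the same as a ring containing nitrogen and two fluorines. No other data here bear on why the two groups read alike. The compounds shown leave open whether a non-aromatic group at this position, such as a piperidine ring or a simple amine, would read the same.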